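This account rests on a few compounds, and the source may have more. Where it says the series, first, only, none or still open, it means among the compounds named here.

Measured so far:
- compound 1, `Cc1cc(NC(=O)Nc2ccc(C)c(Cl)c2)c2ccccc2n1` — 300 nM
- compound 2, `COC(=O)c1cccc(NC(=O)Nc2cc(C)nc3ccccc23)c1` — 600 nM

In a physicochemical assay for solubility, at pH 7.4 (on this read-out lower numbers stand for lower solubility and higher numbers for higher solubility), compound 2 gives the highest of the two numbers; compound 1 gives a number that is within the scatter of it, so the two cannot be told apart. Compound 3, `Cc1cc(NC(=O)Nc2cccc(Cl)c2)c2ccccc2n1`, is not yet measured. It differs from compound 2 in one place: chloro in place of methoxycarbonyl on an aromatic carbon. Going by the values given here, no measured pair shows this change, so the expected step of a 1.7-fold lower number from compound 2 to compound 3 (0.23 log units; within the scatter) is an estimate, a small move towards lower values, close to the scatter, since compound 1 also carries chloro and gives 300 nM. Compound 3 is expected to give 350 nM, between 120 nM and 1000 nM.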

Compound 3, solubility: 800 nM
Compound 3: middle estimate off by 2.3-fold (0.36 log units), on the low side; the range from low to high includes it.
By their numbers in this assay, from the lowest: compounds 1, 2 and 3 (each within the scatter of the next, the first and the last beyond it).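

In this assay chloro in place of methoxycarbonyl on an aromatic carbon gives a 1.3-fold higher number from compound 2 to compound 3 (0.12 log units; within the scatter) and so cannot be told from no change. Hydrogen in place of methyl on an aromatic carbon gives a 2.7-fold higher number from compound 1 to compound 3 (0.43 log units; beyond the scatter) and is the only step here that clears the scatter, though only modestly. Nothing available explains either step.

Going by these compounds, the methyl step rests on one pair, so whether it would hold in a compound carrying methoxycarbonyl stays open. Also open, on these data alone, is how an amine or a carboxylic acid on the chloro-bearing carbon would read in this assay.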